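Pyrrolidin-1-yl for piperidin-1-yl on compound 2

The source may report more compounds than this note shows. Statements on the series, on what has been measured and on what is new or still open speak of the compounds shown alone.

In a functional assay on MCF7 cells (Homo sapiens) for antiproliferative activity, read by CellTiter-Glo, with a stated time of 5 days (on this read-out higher numbers stand for weaker inhibition and lower numbers for stronger inhibition), compound 2 `CC1=C(c2cccc(O)c2)C(c2ccc(OC[C@H](C)N3CCCCC3)cc2)Oc2ccc(O)cc21` gives 0.1 nM and compound 1 `CC1=C(c2cccc(O)c2)C(c2ccc(OC[C@@H](C)N3CCCC3)cc2)Oc2ccc(O)cc21` gives 0.2 nM. These two values sit within the scatter of each other at the low end of the three numbers. Compound 3 `CC1=C(c2ccc(S(C)(=O)=O)cc2)C(c2ccc(OC[C@H](C)N3CC[C@@H](C)C3)cc2)Oc2ccc(O)cc21` gives 27 nM. That number lies well beyond the scatter from both.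

Compound 4 `CC1=C(c2cccc(O)c2)C(c2ccc(OC[C@H](C)N3CCCC3)cc2)Oc2ccc(O)cc21` differs from compound 2 by one change, (pyrrolidin-1-yl in place of piperidin-1-yl on a saturated chain carbon bound to two saturated chain carbons), on a saturated chain carbon bound to two saturated chain carbons. The closest evidence is the same ring exchange in the opposite sense, a 2.0-fold lower number from compound 1 to compound 2 (0.30 log units; within the scatter), although compound 1 and compound 4 are not the same structure. Compound 3 differs in more than this ring and adds little. No step beyond the scatter is therefore expected in this assay. The estimated step is a 2.0-fold higher number from compound 2 to compound 4 (0.30 log units; within the scatter). Compound 4 is estimated at 0.2 nM, with an expected range of 0.07 nM to 0.6 nM.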

Compound 4, half-maximal inhibitory concentration: 0.2 nM
For compound 4 middle estimate and measured number coincide at the digits printed; the range from low to high includes it.
By their numbers in this assay, from the lowest: compounds 2, 1 and 4 (each within the scatter of the next); then compound 3.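

In this assay, the ring exchange on the saturated chain carbon bound to two saturated chain carbons can now be read with the configuration there held constant, and a 2.0-fold higher number from compound 2 to compound 4 (0.30 log units; within the scatter) does not separate pyrrolidin-1-yl from piperidin-1-yl. With pyrrolidin-1-yl held constant, the configuration at that carbon does not separate the compounds either, with no change at the digits printed from compound 1 to compound 4 (within the scatter). That comparison carries one reservation: the fact that one of compounds 1 and 4 is drawn with a defined configuration and the other without, at the place where they differ

Open, going by these compounds, is whether a dimethylamino group or morpholin-4-yl in place of these rings would stay within the same range. Also open, on these data alone, is how piperidin-1-yl reads with the other configuration at this carbon.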